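The compounds below may be only part of what the source reports. "The series", "measured", "known", "first", "only" and "open" are said of these compounds alone.

Within the data shown here, compound 1 `CCn1c(C(=O)NCCCN(C)C)ccc1C(CC)(CC)c1ccc(OCCC(O)(CC)CC)c(C)c1` is the only member of this set with a number rather than a limit: in a functional assay on MCF7 cells (Homo sapiens) for antiproliferative activity, read by MTT assay, with a stated time of 48 h (a higher number here means a weaker inhibitor, a lower number a stronger inhibitor), compound 1 gives 3350 nM. Compound 2 `CCn1c(C(=O)NCC#N)ccc1C(CC)(CC)c1ccc(OCCC(O)(CC)CC)c(C)c1` sits at a limit of this assay, giving > 50000 nM. Compound 3 `CCn1c(C(=O)Nc2cccc(C(F)(F)F)c2)ccc1C(CC)(CC)c1ccc(OCCC(O)(CC)CC)c(C)c1` likewise reaches a limit, giving > 50000 nM. Both changes to the amide-type nitrogen carry the same mark: an at least 14-fold higher number from compound 1 to compound 2 (1.17 log units; beyond the scatter), and an at least 14-fold higher number from compound 1 to compound 3 (1.17 log units; beyond the scatter). Between compounds 2 and 3 the step is a step that the two limits leave unreadable from compound 2 to compound 3. Compound 4 `CCOC(=O)C(CC(=O)OC)NC(=O)c1ccc(C(CC)(CC)c2ccc(OCCC(O)(CC)CC)c(C)c2)n1CC` differs from compound 1 as follows: a group of 11 heavy atoms (7 carbon, 4 oxygen; no ring) in place of a group of 6 heavy atoms (5 carbon, 1 nitrogen; no ring), on an amide-type nitrogen. Here the 3-(dimethylamino)propyl is again removed from the amide-type nitrogen, the very change that in compound 2 and in compound 3 led to a limit, as the evidence of the limit of > 50000 nM in this assay, at which 2 of the 3 values shown sit, shows. A large rise in number is therefore expected for compound 4 in this assay, most likely beyond the limit, with a 15-fold higher number from compound 1 to compound 4 (1.17 log units; beyond the scatter) from compound 1. The estimated value for compound 4 in this assay is 50000 nM, with a range from 15000 nM to 200000 nM.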

Compound 4, half-maximal inhibitory concentration: 390 nM
For compound 4 the middle estimate is 130-fold (2.11 log units) above the measured one; measured number below the stated range.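

In this assay the group of 11 heavy atoms on the amide-type nitrogen gives an 8.6-fold lower number from compound 1 to compound 4 (0.93 log units; beyond the scatter) and so shows that removing the 3-(dimethylamino)propyl does not in itself lead to the limit. What enters at this place therefore matters: the step is an at least 120-fold lower number from compound 3 to compound 4 (2.10 log units; beyond the scatter) against the 3-(trifluoromethyl)phenyl and an at least 120-fold lower number from compound 2 to compound 4 (2.10 log units; beyond the scatter) against the cyanomethyl. Compound 2 and compound 3 enter these two steps only as limits of the assay.

Nothing given here explains how the group of 11 heavy atoms gives this result. Also open, as far as these compounds go, is which part of that group goes with the lower number, and whether a carboxylic acid within it, or a longer chain or a primary amine on the amide-type nitrogen, would give a similar value.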